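The source may report more compounds than this note shows. Statements on the series, on what has been measured and on what is new or still open speak of the compounds shown alone.

Measured compounds:
- compound 1, `COc1ccc(CN(C(=O)C(C)Br)c2cc(OC)c(OC)c(OC)c2)cc1O`: 120 nM
- compound 2, `C/C=C/C(=O)N(Cc1ccc(OC)c(OC)c1)c1cc(OC)c(OC)c(OC)c1`: 20100 nM
- compound 3, `COc1cc(NCc2cccc(O)c2)cc(OC)c1OC`: 57600 nM

In a functional assay on MGC-803 cells (Homo sapiens) for inhibition, read by MTT assay, with a stated time of 48 h (a lower number here means a stronger inhibitor, a higher number a weaker inhibitor), compound 1 gives the lowest number of the three, with compound 2 and compound 3 both lying far beyond the scatter above it. Compound 4, `COc1ccc(CN(C(=O)CCCl)c2cc(OC)c(OC)c(OC)c2)cc1O`, has not yet been measured. It differs from compound 1 in one place: 2-chloroethyl in place of 1-bromoethyl on a carbonyl carbon. Going by the values given here, no measured pair shows this exact change, so the size of the step is uncertain. The expectation is a step toward a higher number in this assay, beyond the scatter, from compound 1 to compound 4 of a 7.5-fold higher number from compound 1 to compound 4 (0.88 log units; beyond the scatter). Compound 4 is therefore estimated at 900 nM, within a range from 150 nM to 6000 nM.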

Compound 4, half-maximal inhibitory concentration: 140 nM
Compound 4: middle estimate off by 6.4-fold (0.81 log units), on the high side; the measured number lies below the stated range.
By their numbers in this assay, from the lowest: compounds 1 and 4 (each within the scatter of the next); then compound 2; then compound 3.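

In this assay, 2-chloroethyl in place of 1-bromoethyl on a carbonyl carbon gives a 1.2-fold higher number from compound 1 to compound 4 (0.07 log units; within the scatter), a step within the scatter, so this position tolerates this swap of one halogen-bearing chain for the other. The swap alters both the halogen and where it sits on the chain, and these two alterations cannot be read apart from this one pair. No measurement at hand explains the result.

As far as these compounds go, whether a halogen is needed here at all remains open. A plain ethyl group or an amine on this carbonyl carbon would speak to that.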